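Half-life notes: from compound 2 to compound 4

The compounds below may be only part of what the source reports. "The series", "measured", "known", "first", "only" and "open" are said of these compounds alone.

Measured in an ADME assay on microsomes from liver (Homo sapiens) for metabolic stability; a lower number here means that the compound disappears faster, a higher number that the compound lasts longer:
- compound 1 `CC(C)[C@@H](c1ccc(-c2ccc3cccc(F)c3c2)[nH]c1=O)[C@@H]1OC(=O)NC1=O`: > 3 h (a limit)
- compound 2 `CC(C)C(c1ccc(-c2ccc3cccc(F)c3c2)[nH]c1=O)C1NC(=O)NC1=O`: 0.578 h
- compound 3 `O=C1NC(=O)/C(=C/C(c2ccc(-c3ccc4cccc(F)c4c3)[nH]c2=O)C2CCCCC2)O1`: 1.09 h

Compound 1 gives > 3 h, which is a limit of the assay. Going by the values given here, only two true numbers are therefore available: compound 2 gives 0.578 h and compound 3 gives 1.09 h, and these lie within the scatter of each other.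

The move to compound 4 `CC(C)C(CC1NC(=O)NC1=O)c1ccc(-c2ccc3cccc(F)c3c2)[nH]c1=O` is (2,5-dioxoimidazolidin-4-yl)methyl in place of 2,5-dioxoimidazolidin-4-yl on a saturated chain carbon bound to an aromatic carbon and a saturated chain carbon. Among the compounds with values here, no measured pair shows this change, so no shift beyond the scatter, in either direction, is expected in this assay. The expected step is a 1.0-fold higher number from compound 2 to compound 4 (0.02 log units; within the scatter). For compound 4 the estimate is 0.6 h, with an expected range from 0.28 h to 1.3 h.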

Compound 4, half-life in the Homo sapiens assay: 1.59 h
Compound 4: the middle estimate sits 2.7-fold (0.42 log units) below what was measured; the whole stated range lies below it.
By their numbers in the Homo sapiens assay, from the lowest: compounds 2, 3 and 4 (each within the scatter of the next, the first and the last beyond it). At a limit, above all of these: compound 1.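

Going by these compounds alone, at this place, on a saturated chain carbon bound to an aromatic carbon and a saturated chain carbon, (2,5-dioxoimidazolidin-4-yl)methyl in place of 2,5-dioxoimidazolidin-4-yl gives the first readable step in the Homo sapiens assay, with compound 2 at 0.578 h and compound 4 at 1.59 h: a 2.8-fold higher number from compound 2 to compound 4 (0.44 log units; beyond the scatter). In a physicochemical assay for solubility, in phosphate buffer, measured as kinetic solubility (a lower number here means a less soluble compound, a higher number a more soluble compound), compound 2 gives 10600 nM and compound 4 gives 12300 nM, and the same change gives a 1.2-fold higher number from compound 2 to compound 4 (0.06 log units; within the scatter), so the two assays do not move together for this pair. Nothing shown gives a cause for the step.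

Still open, as far as these compounds go, is whether a longer chain carrying the same ring continues this trend in half-life. The compounds shown also leave open how a carboxylic acid or an amine in place of the ring would read in either assay.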